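Ring Swap on the Shared Core: Compound 3 to Compound 4

The source may hold more compounds than are shown below. What is called first, only, known or untested is meant among the compounds shown, and "the series" means these compounds.

Three compounds share one core and differ only in the aromatic ring carried on an aromatic carbon of it. Compound 1 `c1cncc(-c2ccccc2OCC2=NCCN2)c1` reaches 109% in a functional assay with Alpha-1A adrenergic receptor (Homo sapiens) as the target, read by calcium flux; on this read-out lower numbers stand for smaller maximal responses and higher numbers for larger maximal responses; compound 2 `c1coc(-c2ccccc2OCC2=NCCN2)c1` reaches 106%; compound 3 `c1csc(-c2ccccc2OCC2=NCCN2)c1` reaches 101%. Compound 3 gives the lowest of the three numbers, yet its distance to compound 2, a number 5 percentage points lower from compound 2 to compound 3 (within the scatter), and to compound 1, a number 8 percentage points lower from compound 1 to compound 3 (within the scatter), both stay within the scatter, so the three compounds cannot be told apart on this read-out. Compound 4 `c1c[nH]c(-c2ccccc2OCC2=NCCN2)c1` is the next step: 1H-pyrrol-2-yl in place of thiophen-2-yl on an aromatic carbon. For the measured compounds named here, the steps that bear on it are the earlier exchanges of one ring for another on that aromatic carbon, a number 3 percentage points lower from compound 1 to compound 2 (within the scatter) and a number 5 percentage points lower from compound 2 to compound 3 (within the scatter), neither of which moved the maximal response beyond the scatter. Putting 1H-pyrrol-2-yl in place of thiophen-2-yl is therefore expected to leave this assay essentially unchanged, with a step of a number 2 percentage points higher from compound 3 to compound 4 (within the scatter). Compound 4 is estimated at 103%, with a range from 90% to 116%.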

Compound 4, largest response reached (reported as maximum), in percent of the reference or control that the assay uses: 99%
For compound 4 the middle estimate is 4 percentage points above the measured one; the measured number falls inside the stated range.
By their numbers in this assay, from the lowest: compounds 4, 3, 2 and 1 (each within the scatter of the next).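

In this assay, for the compounds shown here, the exchange of thiophen-2-yl, with 0 hydrogen-bond donors, for 1H-pyrrol-2-yl, with 1 hydrogen-bond donor, gives a number 2 percentage points lower from compound 3 to compound 4 (within the scatter) and thus shows for the first time that a ring carrying a hydrogen-bond donor on this aromatic carbon leaves the maximal response within the scatter. The wider comparisons agree: the exchange for furan-2-yl gives a number 7 percentage points lower from compound 2 to compound 4 (within the scatter) and the exchange for pyridin-3-yl gives a number 10 percentage points lower from compound 1 to compound 4 (within the scatter) so the four rings cannot be told apart on this read-out. No measurement shown accounts for this lack of separation.

The compounds shown carry only aromatic rings at this place, so the effect of an amine, a carboxylic acid or a longer alkyl chain there stays open. Also open, on these data alone, is how 1-methyl-1H-pyrrol-2-yl, with a methyl group on the ring nitrogen, would compare with compound 4 in this assay.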